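Pyridinylethenyl in place of methyl on the shared core

The source may report more compounds than this note shows. Statements on the series, on what has been measured and on what is new or still open speak of the compounds shown alone.

Compound 2 `Cc1nc2ccccc2nc1OCC(=O)Nc1ccc(Cl)cc1` is known in a functional assay on K562 cells (Homo sapiens) for inhibition, read by MTT assay, with a stated time of 24 h (a higher number here means a weaker inhibitor, a lower number a stronger inhibitor), only as a limit: compound 2 gives > 100000 nM. Compound 1 `O=C(Cn1c(=O)c(/C=C\c2ccncc2)nc2ccccc21)Nc1ccc(Cl)cc1` likewise reaches only a limit, giving > 50400 nM. Between two limits no step can be computed, so compound 2 stands on no number at all. Compound 3 `O=C(COc1nc2ccccc2nc1/C=C\c1ccncc1)Nc1ccc(Cl)cc1` arises from compound 2 by 2-(pyridin-4-yl)ethenyl in place of methyl on an aromatic carbon. Among the measured compounds shown here, no measured step covers this change; with both known values at limits, no step beyond the scatter is expected in either direction. Compound 3 is expected near 80000 nM, within 20000 nM to 200000 nM, the expected step of an at least 1.2-fold lower number from compound 2 to compound 3 (0.09 log units; that floor lies within the scatter) being a guess only.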

Compound 3, half-maximal inhibitory concentration: 49900 nM
Beside the measured number, compound 3's estimate is 1.6-fold (0.20 log units) above it; the measured number falls inside the stated range.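

In this assay, among the compounds shown here, 2-(pyridin-4-yl)ethenyl in place of methyl on this aromatic carbon gives the first value here that is a number and not a limit, with an at least 2.0-fold lower number from compound 2 to compound 3 (0.30 log units; that floor lies within the scatter). The true size of this step stays unknown, because compound 2 is known only as a limit: the limit of > 100000 nM in this assay, at which 1 of the 3 values shown sits.

As far as these compounds go, it remains open whether the ring nitrogen or the double bond of the entering group goes with this value. A 2-phenylethenyl or a 2-(pyridin-4-yl)ethyl group on the same carbon would separate the two.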